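Dimethylcarbamoyl to oxadiazole on the shared core

A few compounds are considered here, and "the series" means these few. Any claim that something is new, unique, unknown or untested is made for them only; others in the source may bear on it.

Measured in a physicochemical assay for solubility, using the shake flask method, in simulated intestinal fluid, measured as kinetic solubility, with a stated time of 2 h, at 25 degrees C, at pH 6.5; a higher number here means a more soluble compound, a lower number a less soluble compound:
compound 1 `CCOC(=O)c1nc(C)c2c(c1N)C(=O)N(Cc1ccccc1)C2=O`: < 5000 nM (a limit of the assay, not a number)
compound 2 `COC(=O)c1nc(C)c2c(c1N)C(=O)N(Cc1ccccc1)C2=O`: 7400 nM
compound 3 `Cc1nc(C(=O)N(C)C)c(N)c2c1C(=O)N(Cc1ccccc1)C2=O`: 172000 nM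

Compound 3, at 172000 nM, stands highest in the series, and its nearest neighbour is compound 2.

Compound 4 `Cc1nc(-c2nc(C(F)(F)F)no2)c(N)c2c1C(=O)N(Cc1ccccc1)C2=O` carries 3-(trifluoromethyl)-1,2,4-oxadiazol-5-yl in place of dimethylcarbamoyl on an aromatic carbon.

Among the compounds with values here, no measured step places this ring, so the evidence is indirect. Two steps install the dimethylcarbamoyl group and are both large: a 23-fold higher number from compound 2 to compound 3 (1.37 log units; beyond the scatter) and an at least 34-fold higher number from compound 1 to compound 3 (1.53 log units; beyond the scatter). By contrast, an at least 1.4-fold higher number from compound 1 to compound 2 (0.17 log units; that floor lies within the scatter). With dimethylcarbamoyl gone, compound 4 is expected to give back a step similar to a 23-fold higher number from compound 2 to compound 3 (1.37 log units; beyond the scatter), so a large fall in this assay is expected. The estimated change is a 34-fold lower number from compound 3 to compound 4 (1.54 log units; beyond the scatter). Compound 4 may also read only as a limit, given (the limit of < 5000 nM in this assay, at which 1 of the 3 values shown sits). Compound 4 is estimated at 5000 nM, with an expected range of 1800 nM to 20000 nM.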

Compound 4, solubility: < 5000 nM
Compound 4 was reported as a limit; the forecaster's own chance of this, stated with the estimate: 45%; the middle value sits exactly at the limit.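

Within the data shown here, on the aromatic carbon next to the ring nitrogen, 3-(trifluoromethyl)-1,2,4-oxadiazol-5-yl is the first group without a carbonyl, and in this assay putting it in place of dimethylcarbamoyl gives an at least 34-fold lower number from compound 3 to compound 4 (1.53 log units; beyond the scatter). Set against methoxycarbonyl, the same ring gives an at least 1.4-fold lower number from compound 2 to compound 4 (0.17 log units; that floor lies within the scatter), so among the four compounds the high reading at this position belongs to dimethylcarbamoyl alone. Compound 4 reads as a limit and not a number, as does compound 1, and the step between them cannot be read: the limit of < 5000 nM in this assay, at which 2 of the 4 values shown sit.

From the compounds shown here alone, how far compound 4 lies from its limit stays unknown, so the ring and the two esters cannot be ranked. Going by these compounds, whether the high reading needs the dimethylamino group itself stays open, and a primary carboxamide, a morpholine amide or a carboxylic acid at this place would address that.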